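Series notes: amide variation on a shared naphthyl core

This account rests on a few compounds, and the source may have more. Where it says the series, first, only, none or still open, it means among the compounds named here.

Measured so far in an assay on LtK cells with ATP-sensitive inward rectifier potassium channel 11 (Homo sapiens) as the target; a higher number here means that more compound is needed for the effect, a lower number that less compound is needed:
Compound 1 `O=C(Nc1c(C(O)(C(F)(F)F)C(F)(F)F)ccc2ccccc12)C1CC1`: 751 nM
Compound 2 `N#Cc1cccc(C(=O)Nc2c(C(O)(C(F)(F)F)C(F)(F)F)ccc3ccccc23)c1`: 12 nM

Compound 2 stands lowest of the two numbers; the step of a 63-fold lower number from compound 1 to compound 2 (1.80 log units; beyond the scatter) is large. Compound 3 `COc1cccc(C(=O)Nc2c(C(O)(C(F)(F)F)C(F)(F)F)ccc3ccccc23)c1` differs from compound 2 by methoxy in place of cyano on an aromatic carbon, on an aromatic carbon meta to a large group. For the measured compounds named here, no measured step varies this position; the only comparison, a 63-fold lower number from compound 1 to compound 2 (1.80 log units; beyond the scatter), exchanges the whole group on the carbonyl carbon and so bears only loosely. A modest shift is therefore expected for compound 3, tending toward a higher number, with estimate 30 nM (range 8 nM to 120 nM), i.e. an expected step of a 2.5-fold higher number from compound 2 to compound 3 (0.40 log units; beyond the scatter).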

Compound 3, half-maximal effective concentration: 185 nM
Compound 3: the middle estimate sits 6.2-fold (0.79 log units) below what was measured; the whole stated range lies below it.
By their numbers in this assay, from the lowest: compound 2; then compound 3; then compound 1.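

Methoxy in place of cyano, a swap of equal heavy-atom count with one hydrogen-bond acceptor on each side, gives a 15-fold higher number from compound 2 to compound 3 (1.19 log units; beyond the scatter) at this aromatic carbon, so this position is sensitive to the choice of group. The gain over cyclopropyl therefore does not come from the phenyl ring alone: 3-methoxyphenyl gives only a 4.1-fold lower number from compound 1 to compound 3 (0.61 log units; beyond the scatter) in this series. Nothing available explains the gap between cyano and methoxy.

As far as these compounds go, whether chlorine, an amine or a carboxylic acid on this carbon would fall nearer compound 2 or compound 3 remains open. So does the effect of moving the cyano group elsewhere on the ring.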